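A few compounds are considered here, and "the series" means these few. Any claim that something is new, unique, unknown or untested is made for them only; others in the source may bear on it.

Compound 1 (`O=C(NCc1ccc(NC(=O)c2ccc(F)cc2N2CCCC2)cc1)OCc1cccnc1`) carries a fluoro group on an aromatic ring of the shared core. In a functional assay on AGS cells (Homo sapiens) for inhibition, read by MTT assay, with a stated time of 72 h (a lower number here means a stronger inhibitor, a higher number a weaker inhibitor), compound 1 gives > 100000 nM as its result, and this is a limit of the assay, not a number. Compound 2 (`O=C(NCc1ccc(NC(=O)c2cc(C(F)(F)F)ccc2N2CCCC2)cc1)OCc1cccnc1`) gives > 100000 nM in the same test, again a limit and not a number. Compound 1 therefore stands where every result so far stands (the limit of > 100000 nM in this assay, at which 2 of the 2 values shown sit) and has no exact value to compare against.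

Compound 3 (`Cc1ccc(C(=O)Nc2ccc(CNC(=O)OCc3cccnc3)cc2)c(N2CCCC2)c1`) has not yet been measured. It has methyl in place of fluoro on an aromatic carbon, meta to a pyrrolidin-1-yl group and para to a large group (methyl in place of fluoro on an aromatic carbon). Going by the values given here, no measured pair gives a size for this swap, so the expectation rests only on compound 1 and compound 2 sharing one limit (the limit of > 100000 nM in this assay, at which 2 of the 2 values shown sit). No shift beyond the usual scatter is expected in either direction, and the expected step is small (a number no higher from compound 1 to compound 3 (the limit leaves the size open)). For compound 3 the estimated value is 100000 nM with an expected range from 50000 nM to 200000 nM and a good chance of another limit.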

Compound 3, half-maximal inhibitory concentration: > 100000 nM
Compound 3 was reported as a limit; the forecaster's own chance of this, stated with the estimate: 80%; the middle value sits exactly at the limit.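

Compound 1 and compound 3 are both reported only as limits in this assay, so no step can be read for methyl in place of fluoro on an aromatic carbon: the limit of > 100000 nM in this assay, at which 3 of the 3 values shown sit. The compounds shown leave open whether any change to the shared core gives an exact value in this assay, and how far fluoro and methyl differ.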